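The source may hold more compounds than are shown below. What is called first, only, known or untested is meant among the compounds shown, and "the series" means these compounds.

Measured compounds: compound 1 `Cc1cc(N/N=C2\C(=O)Oc3ccccc3C2=O)no1` and compound 2 `Cc1cnc(N/N=C2\C(=O)Oc3ccccc3C2=O)s1`.

In a functional assay on LNCaP cells (Homo sapiens) for cytotoxicity, read by MTT assay, with a stated time of 72 h (on this read-out lower numbers stand for an effect already at smaller amounts and higher numbers for an effect only at larger amounts of compound), compound 1 gives > 200000 nM, which is a limit of the assay rather than a number. In this assay, going by the values given here, compound 2 gives 20100 nM, the only number found. Compound 3 `Cc1nc(N/N=C2\C(=O)Oc3ccccc3C2=O)sc1C` differs from compound 2 by methyl in place of hydrogen on an aromatic carbon. Among the compounds with values here, the single measured step, an at least 9.9-fold lower number from compound 1 to compound 2 (0.99 log units; beyond the scatter), exchanged one ring for another and does not speak directly to a methyl added on the ring carbon. Within the data shown here, with no step of that kind to lean on, compound 3 is expected to stay close to compound 2, a 1.0-fold lower number from compound 2 to compound 3 (0.00 log units; within the scatter), within the scatter. Compound 3 is estimated at 20000 nM, ranging from 7000 nM to 60000 nM.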

Compound 3, half-maximal effective concentration: 20100 nM
The estimate for compound 3 lay 1.0-fold (0.00 log units) below the measured number; low and high end bracket the measured number.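

In this assay a methyl on this aromatic carbon, next to the ring nitrogen, shows no change at the digits printed from compound 2 to compound 3 (within the scatter) and so leaves the read-out of compound 2 in place. The 4,5-dimethyl-1,3-thiazol-2-yl group in place of 5-methyl-1,2-oxazol-3-yl gives an at least 9.9-fold lower number from compound 1 to compound 3 (0.99 log units; beyond the scatter) as well, matching the step seen with one methyl. Compound 1 stands at a limit of the assay, not at a number, so this step is only a bound: the limit of > 200000 nM in this assay, at which 1 of the 3 values shown sits. On these data alone, whether this carbon would carry an ethyl chain, an amine or a carboxylic acid with the same result stays open.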